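The compounds below may be only part of what the source reports. "The series", "measured", "known", "first", "only" and "open" are said of these compounds alone.

Within the data shown here, compound 1 `COc1cc2c(cc1OC)CN(S(=O)(=O)c1ccc(-n3cc(COc4ccccc4C(C)=O)nn3)cc1)CC2` is one of three compounds measured so far in a functional assay on HuCC-A1 cells (Homo sapiens) for cytotoxicity, read by MTT assay, with a stated time of 48 h; a higher number here means a weaker inhibitor, a lower number a stronger inhibitor. In this assay compound 1 gives > 50 ug/mL, which is a limit of the assay and not a number. Compound 2 `Cc1ccccc1OCc1cn(-c2ccc(S(=O)(=O)N3CCc4ccccc4C3)cc2)nn1` gives > 50 ug/mL in this assay, again a limit. Compound 3 `O=S(=O)(c1ccc(-n2cc(COc3ccccc3)nn2)cc1)N1CCc2ccccc2C1` gives > 50 ug/mL in this assay, likewise a limit. Compound 1 therefore stands with the other two at the same limit: the limit of > 50 ug/mL in this assay, at which 3 of the 3 values shown sit. Among the measured compounds shown here, the only measured step between compounds that differ in one place, a step that the two limits leave unreadable from compound 2 to compound 3, cannot be read, since both ends sit at that limit.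

The step now followed leads from compound 1 to compound 4 `COc1cc2c(cc1OC)CN(S(=O)(=O)c1ccc(-n3cc(COc4ccccc4)nn3)cc1)CC2`, in which the change is hydrogen in place of acetyl on an aromatic carbon. For the measured compounds named here, the one measured step, from compound 2 to compound 3, also removes a small group from the aromatic ring attached through oxygen, but it yields no readable size, so no expectation of a step beyond the scatter can be drawn from it. Compound 1 sits at the limit, and the best estimate is that compound 4 stays there as well, with an expected step that the limit leaves unreadable from compound 1 to compound 4. Compound 4 is thus expected to give about 80 ug/mL in this assay, within a range from 30 ug/mL to 300 ug/mL.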

Compound 4, half-maximal inhibitory concentration: > 50 ug/mL
Compound 4 was reported as a limit; the forecaster's own chance of this, stated with the estimate: 80%; the middle value does not contradict the limit.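

Compound 4 gives > 50 ug/mL in this assay, a limit of the assay and not a number. The step from compound 1 to compound 4 therefore cannot be read, and both compounds sit at the same limit: the limit of > 50 ug/mL in this assay, at which 4 of the 4 values shown sit.

The compounds shown leave open how strong any of the four is in this assay, and whether removing the acetyl makes any difference there.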